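This account rests on a few compounds, and the source may have more. Where it says the series, first, only, none or still open, it means among the compounds named here.

Measured in a functional assay on HT-29 cells (Homo sapiens) for cytotoxicity, read by MTT assay, with a stated time of 72 h; on this read-out higher numbers stand for weaker inhibition and lower numbers for stronger inhibition:
compound 1 `O=C(Nc1ccc(Oc2ccnc3[nH]ccc23)c(F)c1)c1nnn(-c2ccc(F)c(Cl)c2)c1C(F)(F)F`, 630 nM
compound 2 `O=C(Nc1ccc(Oc2ccnc3[nH]ccc23)cc1)c1nnn(-c2ccccc2F)c1C(F)(F)F`, 120 nM
compound 3 `O=C(Nc1ccc(Oc2ccnc3[nH]ccc23)cc1)c1nnn(-c2ccc(F)cc2)c1C(F)(F)F`, 93 nM

Compound 3 carries the lowest of the three numbers in this assay. Compound 2 stands nearest, and the move a 1.3-fold lower number from compound 2 to compound 3 (0.11 log units; within the scatter) is within the scatter, so these two cannot be ordered. Compound 1 stands furthest away, and the gap between compound 1 and compound 3 is beyond the scatter; compound 1 differs from compound 3 in two places, so no single step accounts for it.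

Compound 4 `O=C(Nc1ccc(Oc2ccnc3[nH]ccc23)cc1)c1nnn(-c2ccc(F)c(Cl)c2)c1C(F)(F)F` has not been measured. It differs from compound 3 by chloro in place of hydrogen on an aromatic carbon, placed on an aromatic carbon of a six-membered aromatic ring of carbon only, ortho to a fluoro group and meta to a large group; cut one bond further out this reads 4-fluorophenyl to 3-chloro-4-fluorophenyl. Within the data shown here, no measured step isolates this change. Among the measured compounds shown here, the only single-point step in the set, a 1.3-fold lower number from compound 2 to compound 3 (0.11 log units; within the scatter), concerns the position of a fluoro group and is within the scatter. Compound 1 carries the same 3-chloro-4-fluorophenyl group together with an extra fluoro on the anilide ring and gives 630 nM; the higher number there cannot be assigned to the chloro alone.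

For compound 4 a moderate rise in this assay is expected, the step of a 2.2-fold higher number from compound 3 to compound 4 (0.33 log units; beyond the scatter), with wide uncertainty because compound 1 gives 630 nM while compound 3 gives 93 nM. The estimate for compound 4 is 200 nM, in the range 80 nM to 600 nM.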

Compound 4, half-maximal inhibitory concentration: 1020 nM
Compound 4: the middle estimate sits 5.1-fold (0.71 log units) below what was measured, and the stated range ends below it.
By their numbers in this assay, from the lowest: compounds 3 and 2 (each within the scatter of the next); then compounds 1 and 4 (each within the scatter of the next).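

In this assay, chloro in place of hydrogen on the 4-fluorophenyl group gives an 11-fold higher number from compound 3 to compound 4 (1.04 log units; beyond the scatter), so this carbon, ortho to a fluoro group and meta to a large group, is sensitive to this change. The comparison with the 2-fluorophenyl analogue gives an 8.5-fold higher number from compound 2 to compound 4 (0.93 log units; beyond the scatter), while removing the extra fluoro of compound 1 gives a 1.6-fold higher number from compound 1 to compound 4 (0.21 log units; within the scatter), within the scatter, so that fluoro has no readable effect here and the high number of compound 1 tracks with the 3-chloro-4-fluorophenyl group. No measurement on hand bears on the origin of this shift.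

Open, on these data alone, is whether the shift is particular to chloro or would also appear with a methyl, methoxy or nitrile group on this carbon. Also open, as far as these compounds go, is how chloro would behave on the phenyl ring without the fluoro group.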